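Acetoxymethyl in Place of Phenyl on the Amide Carbonyl

A few compounds are considered here, and "the series" means these few. Any claim that something is new, unique, unknown or untested is made for them only; others in the source may bear on it.

Of the compounds shown here, three sharing one core have been measured in a functional assay on HeLa cells (Homo sapiens) for cytotoxicity, read by MTT assay, with a stated time of 72 h; a higher number here means a weaker inhibitor, a lower number a stronger inhibitor. Compound 1 `O=[N+]([O-])c1ccc(/N=N/Nc2ccc([N+](=O)[O-])cc2Br)c(Br)c1` gives 940 nM, compound 2 `O=C(c1cccc(C(F)(F)F)c1)N(/N=N/c1ccc([N+](=O)[O-])cc1Br)c1ccc([N+](=O)[O-])cc1Br` gives 1120 nM, and compound 3 `O=C(c1ccccc1)N(/N=N/c1ccc([N+](=O)[O-])cc1Cl)c1ccc([N+](=O)[O-])cc1Cl` gives 590 nM. Compound 3 has the lowest of the three numbers, yet its gaps to compound 1 and to compound 2 both lie within the usual scatter, so no order among them can be read. Compound 4 `CC(=O)OCC(=O)N(/N=N/c1ccc([N+](=O)[O-])cc1Cl)c1ccc([N+](=O)[O-])cc1Cl` differs from compound 3 by acetoxymethyl in place of phenyl on a carbonyl carbon. Within the data shown here, no measured pair in this set carries such a change, so its size is open. A small weakening in this assay is expected, probably not beyond the scatter, and the expected step is a 1.4-fold higher number from compound 3 to compound 4 (0.16 log units; within the scatter). Compound 4 is thus estimated at 850 nM, within a range from 300 nM to 2500 nM.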

Compound 4, half-maximal inhibitory concentration: 350 nM
Compound 4: middle estimate off by 2.4-fold (0.39 log units), on the high side; the range from low to high includes it.
By their numbers in this assay, from the lowest: compounds 4, 3, 1 and 2 (each within the scatter of the next, the first and the last beyond it).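

In this assay acetoxymethyl in place of phenyl on a carbonyl carbon gives a 1.7-fold lower number from compound 3 to compound 4 (0.23 log units; within the scatter) and so shows that this position tolerates a group with no ring and two hydrogen-bond acceptors in place of an aromatic ring with none. For this pair, the aromatic ring on the carbonyl is not required for activity at this level. Nothing available explains this result.

The compounds shown leave open how hydroxymethyl, an amine or a longer alkyl chain would read on this carbonyl carbon. They also cannot separate the loss of the ring from the entry of the acetate ester.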